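Extending the Benzoyl Amide: An Estimate for Compound 4

The source may hold more compounds than are shown below. What is called first, only, known or untested is meant among the compounds shown, and "the series" means these compounds.

Measured compounds:
compound 1, `Cc1cn([C@@H]2O[C@H](CO[Si](C)(C)C(C)(C)C)[C@@]3(OS(=O)(=O)C=C3NC(=O)c3ccccc3)[C@H]2O[Si](C)(C)C(C)(C)C)c(=O)n(C)c1=O`, 4910 nM
compound 2, `Cc1cn([C@@H]2O[C@H](CO[Si](C)(C)C(C)(C)C)[C@@]3(OS(=O)(=O)C=C3NCC(=O)C(N)=O)[C@H]2O[Si](C)(C)C(C)(C)C)c(=O)n(C)c1=O`, 9960 nM
compound 3, `Cc1cn([C@@H]2O[C@H](CO[Si](C)(C)C(C)(C)C)[C@@]3(OS(=O)(=O)C=C3NCC(=O)OCc3ccccc3)[C@H]2O[Si](C)(C)C(C)(C)C)c(=O)n(C)c1=O`, 250000 nM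

In a functional assay on CCRF-CEM cells (Homo sapiens) (a higher number here means that more compound is tolerated, a lower number that less compound is tolerated), compound 1 gives the lowest of the three numbers. Compound 2 lies nearest, with a 2.0-fold higher number from compound 1 to compound 2 (0.31 log units; beyond the scatter), and compound 3 furthest, with a 51-fold higher number from compound 1 to compound 3 (1.71 log units; beyond the scatter). Compound 4, `Cc1cn([C@@H]2O[C@H](CO[Si](C)(C)C(C)(C)C)[C@@]3(OS(=O)(=O)C=C3NC(=O)NC(=O)c3ccccc3)[C@H]2O[Si](C)(C)C(C)(C)C)c(=O)n(C)c1=O`, differs from compound 1 by benzamido in place of phenyl on a carbonyl carbon; the benzoyl is thus kept but becomes benzoylcarbamoyl. Going by the values given here, both measured departures from the benzoyl on the amine nitrogen raised the number, the one to compound 2 modestly and the one to compound 3 greatly, so a rise is expected here too, though a smaller one since the benzoyl is retained. Compound 4 is therefore estimated at 9000 nM, within 3500 nM to 30000 nM, which amounts to an expected 1.8-fold higher number from compound 1 to compound 4 (0.26 log units; within the scatter).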

Compound 4, half-maximal cytotoxic concentration: 2290 nM
Beside the measured number, compound 4's estimate is 3.9-fold (0.59 log units) above it, outside the stated range (below it).
By their numbers in this assay, from the lowest: compound 4; then compound 1; then compound 2; then compound 3.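

In this assay, going by these compounds alone, benzamido in place of phenyl on a carbonyl carbon gives the first downward step at this amine nitrogen, a 2.1-fold lower number from compound 1 to compound 4 (0.33 log units; beyond the scatter), so a change here can move the number either way. The lowest number now belongs to compound 4, with a 4.3-fold lower number from compound 2 to compound 4 (0.64 log units; beyond the scatter) and a 110-fold lower number from compound 3 to compound 4 (2.04 log units; beyond the scatter), which places benzoylcarbamoyl below both (carbamoylcarbonyl)methyl and (benzyloxycarbonyl)methyl. No evidence on the reason for these steps is available. The compounds shown leave open whether the terminal phenyl matters to this lower number, as a methyl or cyclohexyl in its place would show.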